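Ring Swap at the Chain Carbon: Stability Outlook

The compounds below may be only part of what the source reports. "The series", "measured", "known", "first", "only" and "open" are said of these compounds alone.

Measured in an ADME assay on microsomes from liver (Mus musculus) for metabolic stability; a lower number here means that the compound disappears faster, a higher number that the compound lasts longer:
- compound 1, `CC(C)C(c1ccc(-c2ccc3cccc(F)c3c2)[nH]c1=O)N1CCN/C1=N\C#N`: 0.207 h
- compound 2, `CC(C)C(CC(N)=O)c1ccc(-c2ccc3cccc(F)c3c2)[nH]c1=O`: < 0.0667 h, which is a limit of the assay and not a number
- compound 3, `CC(C)C(c1cnc(N)s1)c1ccc(-c2ccc3cccc(F)c3c2)[nH]c1=O`: 0.08 h

Compound 3 holds the lowest of the two real numbers in this assay; its nearest neighbour is compound 1, and the step of a 2.6-fold lower number from compound 1 to compound 3 (0.41 log units; beyond the scatter) lies beyond the scatter. Compound 2 stands at the limit of < 0.0667 h in this assay, at which 1 of the 3 values shown sits, so between compound 2 and compound 3 only an at least 1.1-fold higher number from compound 2 to compound 3 (0.07 log units; that floor lies within the scatter) can be stated, and that floor is within the scatter.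

Compound 4, `CC(C)C(Cc1noc(=O)[nH]1)c1ccc(-c2ccc3cccc(F)c3c2)[nH]c1=O`, is not yet measured. It differs from compound 3 by a group of 7 heavy atoms (3 carbon, 2 nitrogen, 2 oxygen; one five-membered aromatic ring with 3 hetero atoms) in place of a group of 6 heavy atoms (3 carbon, 2 nitrogen, 1 sulfur; one five-membered aromatic ring with 2 hetero atoms), on a saturated chain carbon bound to an aromatic carbon and a saturated chain carbon. Within the data shown here, two measured steps touch the same saturated chain carbon: a 2.6-fold lower number from compound 1 to compound 3 (0.41 log units; beyond the scatter) and an at least 1.1-fold higher number from compound 2 to compound 3 (0.07 log units; that floor lies within the scatter). Each exchange of the group at that carbon has so far moved the half-life modestly or not at all, and compound 3 already sits close to the floor of this assay. A step within the scatter is therefore expected, a 1.1-fold higher number from compound 3 to compound 4 (0.05 log units; within the scatter), with some chance that the assay returns only a limit. Compound 4 is estimated at 0.09 h, between 0.05 h and 0.2 h.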

Compound 4, half-life: 2.78 h
Compound 4: middle estimate off by 31-fold (1.49 log units), on the low side; measured number above the stated range.
By their numbers in this assay, from the lowest: compound 3; then compound 1; then compound 4. At a limit, below all of these: compound 2.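

In this assay, the group on this saturated chain carbon proves able to move the half-life far more than the earlier exchanges suggested, with the large step of a 35-fold higher number from compound 3 to compound 4 (1.54 log units; beyond the scatter) and the equally large step a 13-fold higher number from compound 1 to compound 4 (1.13 log units; beyond the scatter). Both groups in the first of these steps are five-membered aromatic rings with the same counts of hydrogen-bond donors and acceptors, so neither the presence of such a ring nor those counts settle the outcome at this position. The step of an at least 41-fold higher number from compound 2 to compound 4 (1.61 log units; beyond the scatter) is large as well, though it is only a floor, and compound 2 stands at a limit of the assay, not a number: the limit of < 0.0667 h in this assay, at which 1 of the 4 values shown sits.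

The compounds shown do not separate the effect of the ring from that of the extra saturated chain carbon in the group of compound 4, since 2-amino-1,3-thiazol-5-yl appears only directly on the chain carbon. Going by these compounds, whether a carboxylic acid or a tetrazole at the end of the same chain would keep a half-life like that of compound 4 also remains open.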